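The source may hold more compounds than are shown below. What is called first, only, known or untested is meant among the compounds shown, and "the series" means these compounds.

Working notes on the series, measured in a functional assay on SK-BR-3 cells (Homo sapiens) for antiproliferative activity, read by MTT assay, with a stated time of 72 h; a lower number here means a stronger inhibitor, a higher number a weaker inhibitor. Compound 1 `C/C=C1/[C@H](O[C@@H]2O[C@H](CO)[C@@H](O)[C@H](O)[C@H]2O)OC=C(C(=O)OC)[C@H]1CC(=O)OCCc1ccc(O)c(O)c1` gives 160000 nM. Compound 2 `C/C=C1/[C@H](O[C@@H]2O[C@H](CO)[C@@H](O)[C@H](O)[C@H]2O)OC=C(C(=O)OC)[C@H]1CC(=O)OCCC1CCCCC1` gives 2000 nM; the step is an 80-fold lower number from compound 1 to compound 2 (1.90 log units; beyond the scatter). Compound 3 `C/C=C1/[C@H](O[C@@H]2O[C@H](COC(C)=O)[C@@H](OC(C)=O)[C@H](OC(C)=O)[C@H]2OC(C)=O)OC=C(C(=O)OC)[C@H]1CC(=O)OCCC1CCCCC1` returns only a limit, > 15000 nM. Compound 3 thus stands at the limit of > 15000 nM in this assay, at which 1 of the 3 values shown sits, the weakest position the numbers allow. Compound 4 `C=C(C)CCOC(=O)C[C@@H]1C(C(=O)OC)=CO[C@@H](O[C@@H]2O[C@H](COC(C)=O)[C@@H](OC(C)=O)[C@H](OC(C)=O)[C@H]2OC(C)=O)/C1=C/C` is unmeasured and differs from compound 3 by 1-methylethenyl in place of cyclohexyl on a saturated chain carbon, two bonds along the chain from an oxygen next to a carbonyl group. Within the data shown here, no measured step changes this group between two numerical values: the only step on this chain carbon, from compound 1 to compound 2, swaps a different pair of groups, and compound 3 itself carries no number. An expected step that the limit leaves unreadable from compound 3 to compound 4, most likely still a limit, is therefore estimated. Compound 4 is estimated at 30000 nM, within 8000 nM to 150000 nM.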

Compound 4, half-maximal inhibitory concentration: > 15000 nM
Compound 4: no number, only a limit; the forecaster's own chance of this, stated with the estimate: 70%; the middle value lies beyond the limit too.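

Compound 3 and compound 4 each return only a limit, so no step between them can be read: the limit of > 15000 nM in this assay, at which 2 of the 4 values shown sit.

The compounds shown leave open how 1-methylethenyl and cyclohexyl compare at this position on the saturated chain carbon.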